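A few compounds are considered here, and "the series" means these few. Any claim that something is new, unique, unknown or untested is made for them only; others in the source may bear on it.

Of the compounds shown here, three have been tested in an ADME assay on MT4 cells (Homo sapiens) for cytotoxicity, read by XTT assay, with a stated time of 5 days (on this read-out higher numbers stand for lower toxicity in this test and lower numbers for higher toxicity in this test), so far: compound 1 (`CNC(=O)[C@@H](NC(=O)[C@](O)(CCCN(Cc1ccc(Br)cc1)NC(=O)[C@@H](NC(=O)OC)C(C)(C)C)Cc1ccccc1)C(C)(C)C`), compound 2 (`CNC(=O)[C@@H](NC(=O)[C@@](O)(CCCN(Cc1ccc(Br)cc1)NC(=O)[C@@H](NC(=O)OC)C(C)(C)C)Cc1ccccc1)C(C)C`) and compound 3 (`CNC(=O)[C@@H](NC(=O)[C@@](O)(CCCN(Cc1ccc(-c2cccnc2)cc1)NC(=O)[C@@H](NC(=O)OC)C(C)(C)C)Cc1ccccc1)C(C)(C)C`). Compound 1 reads > 10000 nM here, which is a limit of the test. Compound 2 reads > 10000 nM here, again a limit. Compound 3 reads > 50000 nM here, also a limit, so it stands on no exact number. Compound 4 (`CNC(=O)[C@@H](NC(=O)[C@@](O)(CCCN(Cc1ccc(-c2ccccn2)cc1)NC(=O)[C@@H](NC(=O)OC)C(C)(C)C)Cc1ccccc1)C(C)(C)C`) carries pyridin-2-yl in place of pyridin-3-yl on an aromatic carbon. Going by the values given here, no measured pair shows what this swap does, so no change beyond the usual scatter is expected in this assay in either direction. The expected step is (a number no higher from compound 3 to compound 4 (the limit leaves the size open)). For compound 4 the estimated value is 50000 nM within an expected range (25000 nM to 100000 nM).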

Compound 4, half-maximal cytotoxic concentration: > 50000 nM
Compound 4 ended at the assay's limit; the forecaster's own chance of this, stated with the estimate: 85%; the middle value sits exactly at the limit.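

Compound 3 and compound 4 both read as limits rather than exact numbers, so no step can be read between them. On these data alone, whether swapping pyridin-3-yl for pyridin-2-yl changes toxicity in this test at all stays open.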